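Chloro substitution: working notes on four compounds

A few compounds are considered here, and "the series" means these few. Any claim that something is new, unique, unknown or untested is made for them only; others in the source may bear on it.

Measured so far:
- compound 1 `O=C(CCCCC(S)CCS)Nc1ccccc1`: 8.37%
- compound 2 `O=C(CCCCC(S)CCS)Nc1ccc(Cl)cc1`: 22%
- compound 3 `O=C(CCCCC(CCSC(=O)c1ccccc1)SC(=O)c1ccccc1)Nc1ccccc1`: 11.4%

All numbers come from a functional assay on NCI-H460 cells (Homo sapiens) for inhibition, read by MTT assay, with a stated time of 24 h, tested at 10 ug/mL; a lower number here means less inhibition of growth, a higher number more inhibition of growth at the concentration tested. Compound 1 gives 8.37%, and the change to compound 2, (chloro in place of hydrogen on an aromatic carbon), moves the read-out by a number 13.6 percentage points higher from compound 1 to compound 2 (beyond the scatter). Compound 3 carries a different core; the difference between the core of compound 1 and the core of compound 3 is not broken down here. Compound 3 gives 11.4%, which sits within the scatter of compound 1, while compound 2 stands higher than compound 3 by more than the scatter.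

Compound 4 `O=C(CCCCC(CCSC(=O)c1ccccc1)SC(=O)c1ccccc1)Nc1ccccc1Cl` is not yet measured. It differs from compound 3 by chloro in place of hydrogen on an aromatic carbon. This is the same kind of change as from compound 1 to compound 2, not the same: there the chloro enters para to a large group, here ortho to a large group. Within the data shown here, the one measured case gives a number 13.6 percentage points higher from compound 1 to compound 2 (beyond the scatter); on that basis the step is expected to be about a number 8.6 percentage points higher from compound 3 to compound 4 (within the scatter), with wide uncertainty since the place differs and only one example exists. Compound 4 is estimated at 20% in this assay, between 5% and 38%.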

Compound 4, percent growth inhibition at one concentration: 12.1%
For compound 4 the middle estimate is 7.9 percentage points above the measured one; the range from low to high includes it.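

In this assay the chloro step on the core of compound 3 reads a number 0.7 percentage points higher from compound 3 to compound 4 (within the scatter), set against a number 13.6 percentage points higher from compound 1 to compound 2 (beyond the scatter) on the core of compound 1. Side by side, the two steps cannot be told apart: the same change on two cores in this assay, a number 13.6 percentage points higher (beyond the scatter) from compound 1 to compound 2 and a number 0.7 percentage points higher (within the scatter) from compound 3 to compound 4, 12.9 percentage points apart, within the scatter of two such steps. This does not show that the change carries over from one core to the other with the same size, nor that it fails to carry over, since each core offers a single step and the chloro stands ortho to a large group in compound 4 but at another place in compound 2, leaving core and place unseparated.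

The compounds shown leave open how the chloro would read on the core of compound 3 at the place it holds in compound 2, and whether a repeat of either step would hold. Also open, going by these compounds, is how an amine or a carboxylic acid in place of the chloro would read, or a longer chain in place of the one shared by all four compounds.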